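A few compounds are considered here, and "the series" means these few. Any claim that something is new, unique, unknown or untested is made for them only; others in the source may bear on it.

Measured in an assay on striatum with sodium-dependent dopamine transporter (Rattus norvegicus) as the target; a lower number here means a stronger inhibitor, a higher number a weaker inhibitor:
- compound 1, `CN1CC[C@H](c2ccc(Cl)cc2)[C@@H](C(=O)OCCCCCc2ccccc2)C1`; compound 1 gives 53 nM
- compound 2, `CN1CC[C@H](c2ccc(Cl)cc2)C(C(=O)Oc2ccccc2)C1`; compound 2 gives 906 nM
- compound 3, `CCOC(=O)C[C@H]1CN(C)CC[C@@H]1c1ccc(Cl)cc1`; compound 3 gives 79 nM

Compound 3 holds the second highest of the three numbers. Its nearest neighbour is compound 1, whose number is lower by an amount within the scatter, so the two cannot be ordered; its furthest is compound 2, whose higher number lies beyond the scatter. Among the measured compounds, only compound 2 carries a number that stands clearly apart, and it is the one lacking a defined configuration at the ester-bearing ring carbon.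

Compound 4, `CN1CC[C@H](c2ccc(Cl)cc2)[C@@H](CCC(=O)O)C1`, is not yet measured. Compared with compound 3, the change is carboxymethyl in place of ethoxycarbonyl on a saturated chain carbon bound to a saturated ring carbon, so the ester becomes a free acid and the chain grows by one carbon. Going by the values given here, no measured pair shows this change, and nothing gives a direct read on an acid; the esters of compound 1 and compound 3 sit close together, while compound 2 is the only weaker member.

The expected step from compound 3 to compound 4 in this assay is a 10-fold higher number from compound 3 to compound 4 (1.01 log units; beyond the scatter), toward a weaker inhibitor, with wide uncertainty. Compound 4 is estimated at 800 nM, expected to fall between 150 nM and 4000 nM.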

Compound 4, inhibition constant: 1300 nM
For compound 4 the middle estimate is 1.6-fold (0.21 log units) below the measured one; measured number inside the range.
By their numbers in this assay, from the lowest: compounds 1 and 3 (each within the scatter of the next); then compounds 2 and 4 (each within the scatter of the next).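

In this assay, going by these compounds alone, exchanging (ethoxycarbonyl)methyl for 2-carboxyethyl, on a saturated chain carbon bound to a saturated ring carbon, gives a 16-fold higher number from compound 3 to compound 4 (1.22 log units; beyond the scatter) and so provides the first step between compounds that differ in one place. This position is therefore not indifferent to what the chain carries: the exchange of an ethyl ester for a free carboxylic acid on a longer chain comes with a large loss of inhibition, a step well beyond the scatter. Nothing available here accounts for the size of this step.

Within the data shown here, the single step joins two changes, the end group and the chain length, so it remains open which of them carries the loss; an ethyl ester on the 2-carboxyethyl chain and a carboxylic acid on the shorter chain of compound 3 would each isolate one of the two. Also open, from the compounds shown here alone, is how a primary amide or a primary alcohol at the end of this chain would read against compound 3 on the same core.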